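Swapping the aniline substituent on a quinazoline-type antiproliferative series

The source may report more compounds than this note shows. Statements on the series, on what has been measured and on what is new or still open speak of the compounds shown alone.

Of the compounds shown here, two have been measured in a functional assay on NCI-H1975 cells (Homo sapiens) for antiproliferative activity, read by MTT assay, with a stated time of 72 h; a lower number here means a stronger inhibitor, a higher number a weaker inhibitor. Compound 1 `COc1cc2ncnc(Nc3ccc(Br)cc3)c2cc1OCCCCC(=O)Nc1ccc(S(N)(=O)=O)cc1` gives 23300 nM. Compound 2 `COc1ccc(Nc2ncnc3cc(OC)c(OCCCCC(=O)Nc4ccc(S(N)(=O)=O)cc4)cc23)cc1` gives 30200 nM, the higher of the two numbers, though the gap a 1.3-fold higher number from compound 1 to compound 2 (0.11 log units; within the scatter) is within the scatter, so the two cannot be told apart. Compound 3 `COc1cc2ncnc(Nc3cccc(C)c3)c2cc1OCCCCC(=O)Nc1ccc(S(N)(=O)=O)cc1` has not yet been measured. It differs from compound 2 in one place: 3-methylphenyl in place of 4-methoxyphenyl on a nitrogen on an aromatic ring. For the measured compounds named here, the only measured step, from bromo to methoxy on the same aromatic ring, moved the number by an amount within the scatter, and no other step speaks to a methyl group at this position. The estimate therefore rests on that single small step. Compound 3 is expected to give about 25000 nM, with a range from 9000 nM to 70000 nM. The expected step of a 1.2-fold lower number from compound 2 to compound 3 (0.08 log units; within the scatter) is thus no change beyond the scatter.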

Compound 3, half-maximal inhibitory concentration: 32100 nM
The estimate for compound 3 lay 1.3-fold (0.11 log units) below the measured number; the measured number falls inside the stated range.
By their numbers in this assay, from the lowest: compounds 1, 2 and 3 (each within the scatter of the next).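

In this assay the step of a 1.1-fold higher number from compound 2 to compound 3 (0.03 log units; within the scatter) comes with 3-methylphenyl in place of 4-methoxyphenyl, and the step of a 1.4-fold higher number from compound 1 to compound 3 (0.14 log units; within the scatter) comes with 3-methylphenyl in place of 4-bromophenyl. For the compounds shown here, the earlier pair compared only two groups of the 4-substituted phenyl kind, whereas this change brings in a 3-substituted phenyl and replaces a group with one hydrogen-bond acceptor by a group with none. Even so, 3-methylphenyl, 4-methoxyphenyl and 4-bromophenyl on this nitrogen cannot be told apart by their numbers.

As far as these compounds go, whether an amine or a carboxylic acid on this phenyl ring would give a step beyond the scatter remains open. No measurement at hand offers a reason why these three groups cannot be separated.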